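From Compound 1 to Compound 3: a Larger Amide Group

This account rests on a few compounds, and the source may have more. Where it says the series, first, only, none or still open, it means among the compounds named here.

Of the compounds shown here, two have so far been tested in a functional assay on the whole organism (blood) with Rattus norvegicus as the target, with stated times of 24 h and 1 h, at a dose of 15 mg/kg by the intraperitoneal route; a lower number here means a weaker effect, a higher number a stronger effect of the compound at the dose given. Compound 1, `O=C(NC[C@@H]1C[C@@H]2C=C[C@@H]1C2)NS(=O)(=O)N1CCC(CCNC(=O)c2cnsc2)CC1`, gives 14%. Compound 2, `Cn1cc(C(=O)NCCC2CCN(S(=O)(=O)NC(=O)NC3CCCCC3)CC2)c(=O)n(C)c1=O`, gives 15%. These two values lie within the scatter of each other, so compound 1 cannot be told apart from compound 2; both show only a weak effect at this dose.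

Compound 3, `Cn1cccc(C(=O)NCCC2CCN(S(=O)(=O)NC(=O)NC[C@@H]3C[C@@H]4C=C[C@@H]3C4)CC2)c1=O`, has not yet been measured. It is compound 1 with a single change: a group of 8 heavy atoms (6 carbon, 1 nitrogen, 1 oxygen; one six-membered aromatic ring with 1 hetero atom) in place of a group of 5 heavy atoms (3 carbon, 1 nitrogen, 1 sulfur; one five-membered aromatic ring with 2 hetero atoms), on a carbonyl carbon. The group that leaves and the group that enters each hold one aromatic ring with hetero atoms and two hydrogen-bond acceptors, and neither holds a hydrogen-bond donor.

For the measured compounds named here, no step between two measured compounds is known here, so nothing shows how far a change of this kind moves the read-out. The expected step from compound 1 to compound 3, a number 4 percentage points higher from compound 1 to compound 3 (within the scatter), is small and stays within the scatter, in either direction. Compound 3 is therefore estimated to give 18% in this assay, with a range from 5% to 40%.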

Compound 3, a percentage reported as activity, at one dose (the size of the read-out at that dose, not a potency): 40%
Compound 3: middle estimate off by 22 percentage points, on the low side; the measured number falls inside the stated range.
By their numbers in this assay, from the lowest: compounds 1 and 2 (each within the scatter of the next); then compound 3.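

In this assay, replacing the 1,2-thiazol-4-yl group on the carbonyl carbon with the larger group holding one six-membered aromatic ring gives a number 26 percentage points higher from compound 1 to compound 3 (beyond the scatter). For the compounds shown here, this is the first evidence that the read-out responds to a change at this position, since the earlier compounds offered no pair differing in one place. The two groups have the same counts of hydrogen-bond donors and acceptors, so the step comes with other differences: the number and kind of heavy atoms, the ring size, the number of hetero atoms in the ring and the double bond outside the ring, and no measurement here explains the gain.

A single step cannot show which of these differences matters, or whether the read-out would keep rising with further change at this carbonyl carbon. A plain phenyl ring or a pyridin-3-yl group in the same place would help separate ring size from the hetero atoms and the added double bond, while a dimethylamino group would test whether an aromatic ring is needed there at all.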